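Lengthening the Chain Carbon of Compound 2 with Hydroxymethyl

The source may hold more compounds than are shown below. What is called first, only, known or untested is meant among the compounds shown, and "the series" means these compounds.

Compound 1 `COc1cccc(Sc2c(NS(=O)(=O)c3ccc(C(C)(C)C)cc3)noc2CCCC(=O)O)c1`: 4300 nM
Compound 2 `COc1cccc(Sc2c(NS(=O)(=O)c3ccc(C(C)(C)C)cc3)noc2C)c1`: 530 nM

In an assay on A7R5 cells for displacement of a labelled ligand from Endothelin-1 receptor (Rattus norvegicus) (a higher number here means a weaker inhibitor, a lower number a stronger inhibitor), compound 2 holds the lowest of the two numbers. Among the measured compounds shown here, the only measured step, an 8.1-fold lower number from compound 1 to compound 2 (0.91 log units; beyond the scatter), came from hydrogen in place of 2-carboxyethyl on a saturated chain carbon bound to an aromatic carbon, so removing a longer chain there gave stronger binding. Compound 3 `COc1cccc(Sc2c(NS(=O)(=O)c3ccc(C(C)(C)C)cc3)noc2CCO)c1` differs from compound 2 by hydroxymethyl in place of hydrogen on a saturated chain carbon bound to an aromatic carbon. Since a longer chain at this carbon weakened binding before, a smaller weakening is expected in this assay here. Compound 3 is therefore estimated at 1100 nM, between 450 nM and 3000 nM, an expected step of a 2.1-fold higher number from compound 2 to compound 3 (0.32 log units; beyond the scatter).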

Compound 3, half-maximal inhibitory concentration: 770 nM
Compound 3: middle estimate off by 1.4-fold (0.15 log units), on the high side; low and high end bracket the measured number.
By their numbers in this assay, from the lowest: compounds 2 and 3 (each within the scatter of the next); then compound 1.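

In this assay, a 1.5-fold higher number from compound 2 to compound 3 (0.16 log units; within the scatter), so hydroxymethyl on this chain carbon is accepted as well as hydrogen, and a chain here need not cost binding. By contrast, a 5.6-fold lower number from compound 1 to compound 3 (0.75 log units; beyond the scatter), which changes both the chain length and its end group, so the two effects cannot be separated. An amine at the end of the 2-hydroxyethyl chain, or a hydroxy group on a chain as long as that of compound 1, would help to tell them apart. Nothing available explains these numbers.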